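Amide-side changes within the shared core series

This account rests on a few compounds, and the source may have more. Where it says the series, first, only, none or still open, it means among the compounds named here.

Going by the values given here, compound 2 `Cc1ccc(CN(C)C(=O)c2nn(-c3ccc(F)cc3)c(OC[C@@H](O)C[C@@H](O)CC(=O)O)c2C(C)C)cc1` gives 37 nM in an assay on microsomes from liver for inhibition of 3-hydroxy-3-methylglutaryl-coenzyme A reductase (Rattus norvegicus) (a higher number here means a weaker inhibitor, a lower number a stronger inhibitor), the highest of the three numbers measured so far. Compound 1 `CC(C)c1c(C(=O)NCC2CCCCC2)nn(-c2ccc(F)cc2)c1OC[C@@H](O)C[C@@H](O)CC(=O)O` gives 17 nM in this assay, and compound 3 `CC(C)c1c(C(=O)NCc2ccccc2Cl)nn(-c2ccc(F)cc2)c1OC[C@@H](O)C[C@@H](O)CC(=O)O` gives 9.5 nM. The measured steps read a 2.2-fold higher number from compound 1 to compound 2 (0.34 log units; beyond the scatter) and a 3.9-fold lower number from compound 2 to compound 3 (0.59 log units; beyond the scatter), while a 1.8-fold lower number from compound 1 to compound 3 (0.25 log units; within the scatter). Compound 4 `CC(C)c1c(C(=O)N(C)Cc2ccc(F)c(F)c2)nn(-c2ccc(F)cc2)c1OC[C@@H](O)C[C@@H](O)CC(=O)O` differs from compound 2 in one place: 3,4-difluorophenyl in place of 4-methylphenyl on a saturated chain carbon bound to an amide-type nitrogen. Among the compounds with values here, no measured step alters only the aromatic ring while the methyl on the amide-type nitrogen is kept; the closest case, a 1.8-fold lower number from compound 1 to compound 3 (0.25 log units; within the scatter), stays within the scatter. No step beyond the scatter is therefore expected, a 1.2-fold lower number from compound 2 to compound 4 (0.09 log units; within the scatter). Compound 4 is estimated at 30 nM in this assay, with a range from 12 nM to 75 nM.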

Compound 4, half-maximal inhibitory concentration: 5.7 nM
Compound 4: middle estimate off by 5.3-fold (0.72 log units), on the high side; measured number below the stated range.
By their numbers in this assay, from the lowest: compounds 4, 3 and 1 (each within the scatter of the next, the first and the last beyond it); then compound 2.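

Keeping the methyl on the amide-type nitrogen, 3,4-difluorophenyl in place of 4-methylphenyl on the saturated chain carbon gives a 6.5-fold lower number from compound 2 to compound 4 (0.81 log units; beyond the scatter) in this assay, so the aromatic ring alone moves the number at this position. That methyl therefore does not fix the number of compound 2: (3,4-difluorobenzyl)(methyl)amino gives a 1.7-fold lower number from compound 3 to compound 4 (0.22 log units; within the scatter) and also a 3.0-fold lower number from compound 1 to compound 4 (0.47 log units; beyond the scatter) in this series. No evidence is available to account for the ring change.

Open, on these data alone, is whether a single fluorine suffices, and whether a pyridine ring or a longer chain on the amide nitrogen holds the number.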